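The source may report more compounds than this note shows. Statements on the series, on what has been measured and on what is new or still open speak of the compounds shown alone.

Measured in a functional assay on NCI-H2009 cells (Homo sapiens) for cytotoxicity, read by fluorescence, with a stated time of 48 h; on this read-out higher numbers stand for weaker inhibition of growth and lower numbers for stronger inhibition of growth:
compound 1 `COc1cc(C(=O)/C=C/c2ccc(O)c(O)c2)cc(OC)c1OC`: 1100 nM
compound 2 `COc1ccc(/C=C/C(=O)c2cc(OC)c(OC)c(OC)c2)cc1OCCO`: 3300 nM

Compound 1 holds the lower of the two numbers, and the gap up to compound 2 lies beyond the scatter. Compound 3 `COc1cc(C(=O)/C=C/c2cccc(O)c2)cc(OC)c1OC` is still to be measured. It differs from compound 1 by hydrogen in place of hydroxy on an aromatic carbon, ortho to a hydroxy group and para to a large group, taking 3,4-dihydroxyphenyl to 3-hydroxyphenyl. Within the data shown here, no measured pair shows this change, so the expectation is loose. Among the measured compounds shown here, the only hint is that compound 2, with no hydroxy on that aromatic ring, gives 3300 nM. A modest move towards weaker inhibition of growth in this assay is expected, estimated as a 1.8-fold higher number from compound 1 to compound 3 (0.26 log units; within the scatter). For compound 3 the estimated value is 2000 nM, with an expected range of 600 nM to 7000 nM.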

Compound 3, concentration for 50% growth inhibition: 4200 nM
Beside the measured number, compound 3's estimate is 2.1-fold (0.32 log units) below it, within the range that was stated.
By their numbers in this assay, from the lowest: compound 1; then compounds 2 and 3 (each within the scatter of the next).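

In this assay, hydrogen in place of hydroxy on the aromatic carbon ortho to a hydroxy group and para to a large group gives a 3.8-fold higher number from compound 1 to compound 3 (0.58 log units; beyond the scatter), the first one-place step read in this series. The change from 3,4-dihydroxyphenyl to 3-hydroxyphenyl therefore weakens growth inhibition beyond the scatter, so the hydroxy that leaves counts at this position and the one that remains does not by itself keep the level of compound 1. No measurement accompanies this step that would explain it.

Still open, on these data alone, is whether an amine or a fluorine at this position would keep the level of compound 1 or follow hydrogen. Also open, as far as these compounds go, is the matching change at the remaining hydroxy, with hydrogen in its place and the hydroxy studied here retained.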